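The compounds below may be only part of what the source reports. "The series", "measured", "known", "first", "only" and "open" are said of these compounds alone.

Measured in a functional assay on K562 cells (Homo sapiens) for cytotoxicity, read by MTT assay, with a stated time of 72 h; on this read-out higher numbers stand for weaker inhibition and lower numbers for stronger inhibition:
- compound 1 `COc1cccc(COc2ccc3cc(C(=O)/C=C/c4cccc(OC)c4OC)c(=O)oc3c2)c1`: 45500 nM
- compound 2 `COc1cccc(/C=C/C(=O)c2cc3cc(O)ccc3oc2=O)c1OC`: 17300 nM
- compound 3 `COc1cc(/C=C/C(=O)c2cc3ccc(O)cc3oc2=O)cc(OC)c1OC`: 7300 nM

Compound 1 stands at the highest number of the three, that is, at the weakest inhibition in this assay. Its nearest neighbour is compound 2, whose number lies below it by more than the scatter, and compound 3 lies further below still, also beyond the scatter. Nothing is given on what carries these gaps, since compound 2 and compound 3 differ from compound 1 in more than one place.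

Compound 4 `COc1ccc(/C=C/C(=O)c2cc3ccc(OCc4cccc(OC)c4)cc3oc2=O)cc1` has not yet been measured in this assay. It differs from compound 1 in one place: 4-methoxyphenyl in place of 2,3-dimethoxyphenyl on a double-bonded chain carbon bound to a double-bonded chain carbon. Going by the values given here, no pair of measured compounds differing only at this place exists here, so the size of the step cannot be read from the series. The expectation is a small step for the move from compound 1 to compound 4, likely toward stronger inhibition but not clearly beyond the scatter, and the estimated step is a 1.5-fold lower number from compound 1 to compound 4 (0.18 log units; within the scatter). For compound 4 the estimated value in this assay is 30000 nM, with a range from 10000 nM to 90000 nM.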

Compound 4, half-maximal inhibitory concentration: > 100000 nM
Compound 4 ended at the assay's limit (the forecaster's own chance of this, stated with the estimate: 10%); middle value at least 3.3-fold (0.52 log units) away from the limit.
By their numbers in this assay, from the lowest: compound 3; then compound 2; then compound 1. At a limit, above all of these: compound 4.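

In this assay compound 4 gives > 100000 nM, which is a limit of the assay and not a number. With 4-methoxyphenyl in place of 2,3-dimethoxyphenyl on a double-bonded chain carbon bound to a double-bonded chain carbon, the series gains its first one-place step, an at least 2.1-fold higher number from compound 1 to compound 4 (0.34 log units; beyond the scatter), so this position responds to the change, in the direction of weaker inhibition. That step gives only a minimum size, and how far it extends cannot be read: the limit of > 100000 nM in this assay, at which 1 of the 4 values shown sits.

The compounds shown leave open how this position responds to an amine or a carboxylic acid on the phenyl ring in place of methoxy. They also leave open whether the same change gives a step of similar direction on the core of compound 2.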